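This account rests on a few compounds, and the source may have more. Where it says the series, first, only, none or still open, it means among the compounds named here.

Working notes on the series. The shared core is that of compound 1 `OC[C@H]1O[C@@H](n2cnc3c(NCc4cccc(F)c4)ncnc32)[C@H](O)[C@@H]1O`, carrying a 3-fluorobenzyl group; in a functional assay on B16 cells (Mus musculus) for antiproliferative activity, with a stated time of 72 h (a higher number here means a weaker inhibitor, a lower number a stronger inhibitor), compound 1 has no result, recorded as "not determined" (no result reported). Two neighbours are measured. Compound 2 `OC[C@H]1O[C@@H](n2cnc3c(NCc4cccc(Br)c4)ncnc32)[C@H](O)[C@@H]1O` gives in this assay only a limit, > 166000 nM. Compound 3 `Cc1cccc(CNc2ncnc3c2ncn3[C@@H]2O[C@H](CO)[C@@H](O)[C@H]2O)c1` likewise gives only a limit, > 166000 nM. The step that the two limits leave unreadable from compound 2 to compound 3 is therefore not readable. Going by the values given here, the sole piece of evidence is the limit of > 166000 nM in this assay, at which 2 of the 3 values shown sit, which says nothing about whether a change on the benzyl ring moves potency at all.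

The compound to be measured is compound 4 `COc1cccc(CNc2ncnc3c2ncn3[C@@H]2O[C@H](CO)[C@@H](O)[C@H]2O)c1`, which differs from compound 1 by methoxy in place of fluoro on an aromatic carbon. Among the compounds with values here, no measured step bears directly on this pair; the only neighbouring step, from compound 2 to compound 3, is unreadable, and compound 1 itself has no number. The expectation in this assay is no more than that compound 4 behaves as compounds 2 and 3 do and sits at the limit. Compound 4 is estimated at 200000 nM, within 50000 nM to 800000 nM.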

Compound 4, half-maximal inhibitory concentration: > 166000 nM
Compound 4 gave a limit, no number (the forecaster's own chance of this, stated with the estimate: 85%); the middle value lies beyond the limit too.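

Compound 4, like compound 2 and compound 3, gives only a limit in this assay, so no step among these three compounds can be read: the limit of > 166000 nM in this assay, at which 3 of the 4 values shown sit. The compounds shown leave open whether any change on the benzyl ring moves potency in this assay.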